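A few compounds are considered here, and "the series" means these few. Any claim that something is new, unique, unknown or untested is made for them only; others in the source may bear on it.

Compound 1 `COc1ccc(/C=C2\CCC/C(=C\c3cccc(Cl)c3)C2=O)cc1OC`: 4900 nM
Compound 2 `COc1ccc(/C=C2\CCC/C(=C\c3cccc(O)c3)C2=O)cc1OC`: 1700 nM
Compound 3 `COc1ccc(/C=C2\CCC/C(=C\c3ccc(O)cc3)C2=O)cc1OC`: 16800 nM

In a functional assay on HT-1080 cells (Homo sapiens) for cytotoxicity, read by MTT assay, with a stated time of 72 h (a higher number here means a weaker inhibitor, a lower number a stronger inhibitor), compound 3 gives 16800 nM, the highest number of the three, which makes it the weakest inhibitor of this small set. The next compound, compound 4 `COc1cc(/C=C2\CCC/C(=C\c3ccc(OC)c(OC)c3)C2=O)ccc1O`, is related to it by one change: methoxy in place of hydrogen on an aromatic carbon. In words, this is methoxy in place of hydrogen on an aromatic carbon, so 4-hydroxyphenyl becomes 4-hydroxy-3-methoxyphenyl.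

For the measured compounds named here, no measured step makes this exact change, so the evidence is indirect. Two modest steps end at compound 3: a 3.4-fold higher number from compound 1 to compound 3 (0.54 log units; beyond the scatter) and a 9.9-fold higher number from compound 2 to compound 3 (0.99 log units; beyond the scatter). Each leads from a ring with a group named at the 3-position, in 3-chlorophenyl or 3-hydroxyphenyl, to the 4-hydroxyphenyl ring, and each raises the number. Compound 4 keeps the hydroxy of compound 3 and gains a group at that 3-position. However, neither compound 1 nor compound 2 carries a methoxy there, and a 2.9-fold lower number from compound 1 to compound 2 (0.46 log units; beyond the scatter) shows that the identity of the group matters. A modest fall is therefore expected in this assay, with the estimated change being a 2.8-fold lower number from compound 3 to compound 4 (0.45 log units; beyond the scatter). Compound 4 is estimated at 6000 nM, with an expected range of 2000 nM to 17000 nM.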

Compound 4, half-maximal inhibitory concentration: 4600 nM
For compound 4 the middle estimate is 1.3-fold (0.12 log units) above the measured one, and the stated range covers the measured number.
By their numbers in this assay, from the lowest: compound 2; then compounds 4 and 1 (each within the scatter of the next); then compound 3.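

In this assay, putting methoxy on the 4-hydroxyphenyl ring of compound 3, ortho to a hydroxy group, gives a 3.7-fold lower number from compound 3 to compound 4 (0.56 log units; beyond the scatter). For the compounds shown here, this is the first direct reading at this position, and it shows that the ring carrying the 4-hydroxy group tolerates a methoxy there and that the added group takes the number down rather than up. The gain has limits, however: the 4-hydroxy-3-methoxyphenyl ring still falls short of the 3-hydroxyphenyl ring, with a 2.7-fold higher number from compound 2 to compound 4 (0.43 log units; beyond the scatter), and it cannot be told apart from the 3-chlorophenyl ring, with a 1.1-fold lower number from compound 1 to compound 4 (0.03 log units; within the scatter). The data given offer no measurement that accounts for these shifts.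

Methoxy is the only group seen at this position on the 4-hydroxyphenyl ring, so it remains open whether ethoxy, a fluorine atom or an amine in the same place would move the number in the same direction or by a similar amount. As far as these compounds go, it also remains open whether the hydroxy group is needed for this fall, since no ring here carries the methoxy with a hydrogen, a carboxylic acid or an amine in place of that hydroxy.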